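The source may hold more compounds than are shown below. What is called first, only, known or untested is meant among the compounds shown, and "the series" means these compounds.

Measured compounds:
compound 1 `Cc1ccc(-c2cn(C/C=C3\OC(=O)C(OCc4ccccc4)=C3OCc3ccccc3)nn2)cc1` — > 100000 nM
compound 2 `COc1ccc(-c2cn(C[C@H](O)[C@H]3OC(=O)C(OCc4ccccc4)=C3OCc3ccccc3)nn2)cc1` — > 100000 nM
compound 3 `O=C1O[C@H]([C@@H](O)Cn2cc(-c3cc(C(F)(F)F)cc(C(F)(F)F)c3)nn2)C(OCc2ccccc2)=C1OCc1ccccc1` — 57200 nM

The three compounds were tested in a functional assay on HCT-116 cells (Homo sapiens) for antiproliferative activity, read by MTT assay, with a stated time of 72 h; a lower number here means a stronger inhibitor, a higher number a weaker inhibitor. Compound 1 `Cc1ccc(-c2cn(C/C=C3\OC(=O)C(OCc4ccccc4)=C3OCc3ccccc3)nn2)cc1` gives only a limit of the assay, > 100000 nM. Compound 2 `COc1ccc(-c2cn(C[C@H](O)[C@H]3OC(=O)C(OCc4ccccc4)=C3OCc3ccccc3)nn2)cc1` likewise gives only a limit, > 100000 nM. Compound 3 `O=C1O[C@H]([C@@H](O)Cn2cc(-c3cc(C(F)(F)F)cc(C(F)(F)F)c3)nn2)C(OCc2ccccc2)=C1OCc1ccccc1`, which carries a 3,5-bis(trifluoromethyl)phenyl group in place of the 4-methoxyphenyl group of compound 2, is the only one of the three with a number rather than a limit; in this assay compound 3 gives 57200 nM. Compound 2 thus stands with compound 1 at the limit of > 100000 nM in this assay, at which 2 of the 3 values shown sit, and nothing in the measured set places it anywhere below that line.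

Compound 4 `CCCCc1cn(C[C@H](O)[C@H]2OC(=O)C(OCc3ccccc3)=C2OCc2ccccc2)nn1` differs from compound 2 in one place: butyl in place of 4-methoxyphenyl on an aromatic carbon. Going by the values given here, no step between two measured compounds sharing this change has been recorded, so the expectation rests on the whole set, in which all three values sit at or near the weak end. The step from compound 2 to compound 4 is expected to be small, a number no higher from compound 2 to compound 4 (the limit leaves the size open), most likely none beyond the scatter. Compound 4 is expected to give about 100000 nM in this assay, with a range from 30000 nM to 300000 nM, and a real chance that only a limit is reported.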

Compound 4, half-maximal inhibitory concentration: 10400 nM
Compound 4: middle estimate off by 9.6-fold (0.98 log units), on the high side; the measured number lies below the stated range.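

Going by these compounds alone, with butyl in place of 4-methoxyphenyl on this aromatic carbon of the five-membered ring, this assay records an at least 9.6-fold lower number from compound 2 to compound 4 (0.98 log units; beyond the scatter), the first step in the set and one beyond the usual scatter. It shows that this position can change the read-out and that an aromatic ring is not required there for a measured number: butyl has no ring, yet compound 4 gives 10400 nM, while compound 3, which keeps an aromatic ring at this place, gives 57200 nM. The true size of the step stays open at one end, since compound 2 gives only a limit: the limit of > 100000 nM in this assay, at which 2 of the 4 values shown sit.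

The compounds shown do not separate the loss of the aromatic ring from the presence of the butyl chain itself, and with a single chain they give no trend with chain length. On these data alone, how the number would respond to a longer chain such as octyl, to a saturated cyclohexyl ring, or to a butyl chain ending in an amine or a carboxylic acid at this position remains open.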